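The source may report more compounds than this note shows. Statements on the series, on what has been measured and on what is new or still open speak of the compounds shown alone.

Compound 1, with the structure `O=S(=O)(Nc1ccc(-c2nc3ccccc3o2)cc1)c1ccccc1Cl`, was tested in an ADME assay on HEK293 cells (Homo sapiens) for cytotoxicity, read by resazurin assay, with a stated time of 48 h; a lower number here means that less compound is tolerated, a higher number that more compound is tolerated. In this assay compound 1 gives > 100000 nM, which is a limit of the assay rather than a measured number. A second compound sharing the same core, compound 2 with the structure `CS(=O)(=O)Nc1ccc2oc(-c3ccccc3)nc2c1`, was tested in the same way. In this assay compound 2 gives > 100000 nM, again a limit and not a number. Within the data shown here, every value shown so far therefore sits at the limit of > 100000 nM in this assay, at which 2 of the 2 values shown sit, and no step between two measured numbers can be drawn from them.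

Compound 3, with the structure `O=S(=O)(Nc1ccc(-c2nc3ccccc3o2)cc1)c1ccc(Cl)c(Cl)c1`, has not yet been measured. It differs from compound 1 in one place: 3,4-dichlorophenyl in place of 2-chlorophenyl on a sulfonyl sulfur. Among the measured compounds shown here, because both measured values sit at the limit of > 100000 nM in this assay, at which 2 of the 2 values shown sit, there is no measured step to lean on for this change. The expectation is that compound 3 will also rest at the limit, so the step of a number no higher from compound 1 to compound 3 (the limit leaves the size open) is expected to be none beyond the scatter. Compound 3 is estimated at 100000 nM, with a range from 40000 nM to 250000 nM.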

Compound 3, half-maximal cytotoxic concentration: > 100000 nM
Compound 3 ended at the assay's limit; the forecaster's own chance of this, stated with the estimate: 75%; the middle value sits exactly at the limit.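

In this assay compound 3 gives > 100000 nM, which is a limit and not a number. No step can be read between compound 1 and compound 3, because both rest at the same limit: the limit of > 100000 nM in this assay, at which 3 of the 3 values shown sit. The compounds shown leave open at what concentration, if any, each of them would harm these cells.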